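Ethyl to Methyl on a Ring Amide Nitrogen

The compounds below may be only part of what the source reports. "The series", "measured", "known", "first", "only" and "open" are said of these compounds alone.

Measured so far:
compound 1 `CN(C)C(=O)CN1CC(c2nc(C(=O)NCc3ccc(F)cc3)c(O)c3ncccc23)CC1=O` — 1.8
compound 2 `CC(C)N1CC(c2nc(C(=O)NCc3ccc(F)cc3)c(O)c3ncccc23)CC1=O` — 2.7
compound 3 `CCN1CC(c2nc(C(=O)NCc3ccc(F)cc3S(C)(=O)=O)c(O)c3ncccc23)CC1=O` — 1.9

In a physicochemical assay for lipophilicity, at pH 7.4 (on this read-out lower numbers stand for lower lipophilicity and higher numbers for higher lipophilicity), compound 3 stands second highest of the three, close to compound 1 and well below compound 2. Compound 4 `CN1CC(c2nc(C(=O)NCc3ccc(F)cc3S(C)(=O)=O)c(O)c3ncccc23)CC1=O` differs from compound 3 by hydrogen in place of methyl on a saturated chain carbon bound to an amide-type nitrogen in a ring, so the ethyl becomes a methyl. Among the measured compounds shown here, the only measured step, a number 0.90 log units higher from compound 1 to compound 2 (beyond the scatter), also alters the group on the same kind of nitrogen, but it exchanges two very different groups and bears only loosely on this one-carbon trim. A loss of one carbon is expected to give a small drop, roughly a number 0.40 log units lower from compound 3 to compound 4 (beyond the scatter), possibly within the scatter. Compound 4 is therefore estimated at 1.5, with a range from 1.1 to 1.9.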

Compound 4, partition coefficient: 1.6
For compound 4 the middle estimate is 0.10 log units below the measured one; the measured number falls inside the stated range.
By their numbers in this assay, from the lowest: compounds 4, 1 and 3 (each within the scatter of the next); then compound 2.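

In this assay, the change from ethyl to methyl on the amide-type nitrogen in a ring gives a number 0.30 log units lower from compound 3 to compound 4 (within the scatter), so removing this one carbon cannot be told apart from repeat-measurement noise. The earlier step on this kind of nitrogen, a number 0.90 log units higher from compound 1 to compound 2 (beyond the scatter), exchanged two very different groups, whereas this pair isolates a single carbon. No evidence shown accounts for the size of this step.

On these data alone, a longer chain such as propyl, or a chain ending in a carboxylic acid or an amine, remains open at this nitrogen. So does a bare hydrogen there.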